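This account rests on a few compounds, and the source may have more. Where it says the series, first, only, none or still open, it means among the compounds named here.

Working notes on the bromo-substituted core series.

Among the measured compounds shown here, compound 3 `CC(C)Cn1nnc2c(Br)cccc21` gives 4.2 mL/min/g in an ADME assay on microsomes from liver (Homo sapiens) for metabolic stability, tested at 2.5 uM (a higher number here means faster removal of the compound, a lower number slower removal), the second highest of the three numbers so far. Compound 1 `Brc1cccc2c1nnn2CC1CCCC1` gives 7.9 mL/min/g in this assay, and the gap to compound 3 is a 1.9-fold lower number from compound 1 to compound 3 (0.27 log units; within the scatter). Compound 2 `Brc1cccc2c1nnn2CC1CC1` gives 1.3 mL/min/g in this assay, and the step is a 3.2-fold higher number from compound 2 to compound 3 (0.51 log units; beyond the scatter). Compound 4 `CCCn1nnc2c(Br)cccc21` is the next case; the change from compound 3 is hydrogen in place of methyl on a saturated chain carbon bound to two saturated chain carbons.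

All three measured steps alter the group on a saturated chain carbon bound to an aromatic nitrogen; the largest, a 6.1-fold lower number from compound 1 to compound 2 (0.78 log units; beyond the scatter), removed two carbons and the smallest is a 1.9-fold lower number from compound 1 to compound 3 (0.27 log units; within the scatter). Removing a single methyl is a smaller change than any of them, so for compound 4 a modest move in this assay, likely within the scatter, is expected: a 1.4-fold lower number from compound 3 to compound 4 (0.15 log units; within the scatter). The expected value for compound 4 is 3 mL/min/g, with a range of 1.3 mL/min/g to 7 mL/min/g.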

Compound 4, intrinsic clearance in a liver preparation (reported as CLH), per the amount of preparation that the assay uses: 4.7 mL/min/g
Estimate against measurement, compound 4: 1.6-fold (0.19 log units) below, and the stated range covers the measured number.
By their numbers in this assay, from the lowest: compound 2; then compounds 3, 4 and 1 (each within the scatter of the next).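

In this assay, hydrogen in place of methyl on a saturated chain carbon bound to two saturated chain carbons (a 1.1-fold higher number from compound 3 to compound 4 (0.05 log units; within the scatter)) does not separate the propyl compound from the isobutyl compound. The ethyl-for-cyclopentyl comparison (a 1.7-fold lower number from compound 1 to compound 4 (0.23 log units; within the scatter)) also stays within the scatter, while the ethyl-for-cyclopropyl comparison (a 3.6-fold higher number from compound 2 to compound 4 (0.56 log units; beyond the scatter)) lies beyond it, so among these four compounds only compound 2 stands apart. No available evidence accounts for this separation.

Still open, on these data alone, is whether a longer chain, such as butyl, would stay with compounds 1, 3 and 4. Also open, as far as these compounds go, is whether cyclobutyl would group with them or with compound 2.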